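The source may hold more compounds than are shown below. What is called first, only, known or untested is meant among the compounds shown, and "the series" means these compounds.

Within the data shown here, in a functional assay on HEY cells (Homo sapiens) for cytotoxicity, read by MTT assay, with a stated time of 72 h (a lower number here means a stronger inhibitor, a higher number a weaker inhibitor), only two compounds with the same core have been measured so far. Compound 1 `N[C@H]1CC[C@H](Nc2c(C(=O)NCc3ccc(Cl)cc3Cl)nc(Br)c3cccnc23)CC1` gives 5000 nM, while compound 2 `N[C@H]1CC[C@H](Nc2c(C(=O)NCc3ccc(Cl)cc3)nc(Br)c3cccnc23)CC1` gives 1000 nM, the lower of the two numbers. These compounds differ by hydrogen in place of chloro on an aromatic carbon, and that change comes with a 5.0-fold lower number from compound 1 to compound 2 (0.70 log units; beyond the scatter).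

Compound 3 `N[C@H]1CC[C@H](Nc2c(C(=O)NCc3cccc(C(F)(F)F)c3)nc(Br)c3cccnc23)CC1` keeps the core of compound 2 and changes one group on a saturated chain carbon bound to an amide-type nitrogen: 3-(trifluoromethyl)phenyl in place of 4-chlorophenyl on a saturated chain carbon bound to an amide-type nitrogen. The 4-chlorobenzyl group of compound 2 thus becomes a 3-(trifluoromethyl)benzyl group.

Among the measured compounds shown here, the one measured step touches this same benzyl group, so it offers the only available guide to size, but it involves no trifluoromethyl group. The data therefore give only weak guidance on direction. A step of about the same size or smaller is expected, with a slight lean toward a higher number, given that compound 2 has the lower value at 1000 nM. The estimated change is a 1.5-fold higher number from compound 2 to compound 3 (0.18 log units; within the scatter). For compound 3, the estimated value is 1500 nM, with an expected range from 500 nM to 5000 nM.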

Compound 3, half-maximal inhibitory concentration: 12000 nM
For compound 3 the middle estimate is 8.0-fold (0.90 log units) below the measured one; measured number outside the range, above it.
By their numbers in this assay, from the lowest: compound 2; then compound 1; then compound 3.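

In this assay, replacing 4-chlorophenyl with 3-(trifluoromethyl)phenyl on the saturated chain carbon bound to an amide-type nitrogen gives a 12-fold higher number from compound 2 to compound 3 (1.08 log units; beyond the scatter) and so makes a weaker inhibitor. Among these compounds, this step is larger than the earlier one, a 5.0-fold lower number from compound 1 to compound 2 (0.70 log units; beyond the scatter), so this group can change the number more strongly than the single chloro change suggested. The listed comparison with the dichloro compound gives a 2.4-fold higher number from compound 1 to compound 3 (0.38 log units; beyond the scatter) and makes compound 3 the weakest of the three, but no measurement shown explains the rise.

This one step changes both the substituent and its printed ring position, and the compounds shown do not separate those two changes. A 3-chlorophenyl or 4-(trifluoromethyl)phenyl group would help pull them apart, while a plain phenyl group or a phenyl group carrying an amine or a carboxylic acid would show whether the trend extends beyond halogen-containing groups.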